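The source may report more compounds than this note shows. Statements on the series, on what has been measured and on what is new or still open speak of the compounds shown alone.

Three compounds of the shared core have numbers in a functional assay on Urethra with Alpha-1A adrenergic receptor (Oryctolagus cuniculus) as the target; a lower number here means a smaller maximal response, a higher number a larger maximal response. Compound 1 `CS(=O)(=O)Nc1ccc(O)c2c1CCCC2c1c[nH]cn1` gives 34% in this assay, compound 3 `CS(=O)(=O)Nc1ccc(F)c2c1CCCC2c1c[nH]cn1` gives 64%, and compound 2 `O=S(=O)(Nc1cccc2c1CCCC2c1c[nH]cn1)C1CC1` gives 51%, the second highest of the three, standing beyond the scatter from both compound 3 and compound 1. Among the measured compounds shown here, the one measured step, a number 30 percentage points higher from compound 1 to compound 3 (beyond the scatter), concerns a substituent on an aromatic carbon and leaves the sulfonamide part untouched. Compound 4 `CCS(=O)(=O)Nc1cccc2c1CCCC2c1c[nH]cn1` differs from compound 2 at the sulfonyl sulfur: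

ethyl in place of cyclopropyl on a sulfonyl sulfur

For the measured compounds named here, no measured step touches this sulfonyl group, so nothing speaks to the size of such a change in this assay; the step between compound 1 and compound 3 bears on a different part of the molecule and gives no direction here. With nothing to move the expectation away from the number of compound 2, a step of a number 1 percentage points lower from compound 2 to compound 4 (within the scatter) is expected, none beyond the scatter. Compound 4 is therefore estimated at 50% in this assay, with a range from 35% to 65%.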

Compound 4, largest response reached (reported as efficacy), in percent of the reference or control that the assay uses: 71%
Beside the measured number, compound 4's estimate is 21 percentage points below it; measured number outside the range, above it.
By their numbers in this assay, from the lowest: compound 1; then compound 2; then compounds 3 and 4 (each within the scatter of the next).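

In this assay the substituent on the sulfonyl sulfur proves to be a place where a single change moves the maximal response, with ethyl in place of cyclopropyl giving a number 20 percentage points higher from compound 2 to compound 4 (beyond the scatter). The aromatic carbon carrying hydroxy or fluoro is therefore not the only position in the series with a step beyond the scatter, and here the open ethyl, with no ring and 2 heavy atoms, stands higher than the three-membered ring with 3. Nothing available explains this step, which rests on this single pair of compounds.

Going by these compounds, this pair cannot separate the loss of the ring from the loss of a heavy atom, and whether a propyl chain, an isopropyl group or a phenyl ring on the sulfonyl sulfur would continue or reverse the direction remains open. Also open, on these data alone, is whether the step carries over to compounds with hydroxy or fluoro on the aromatic carbon, since compound 1 and compound 3 differ from compound 2 and compound 4 in more than one place.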